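The source may report more compounds than this note shows. Statements on the series, on what has been measured and on what is new or still open speak of the compounds shown alone.

Three compounds in a functional assay on HTB-54 cells (Homo sapiens) for cytotoxicity, read by MTT assay, with a stated time of 72 h (a lower number here means a stronger inhibitor of growth, a higher number a weaker inhibitor of growth), frame the question. Compound 1 `CSc1ccc(CNc2nc(SC)nc3ncccc23)cc1` gives 3280 nM, compound 3 `COc1ccc(CNc2nc([SeH])nc3ccccc23)cc1` gives 7110 nM, and compound 2 `CCCCC[Se]c1nc(N)c2ccccc2n1` gives 34600 nM. Compound 2 thus stands with the highest number of the three; its gap to compound 3 is beyond the scatter, and its gap to compound 1 is wider still. Compound 4 `C[Se]c1nc(N)c2ccccc2n1` has not been measured; it differs from compound 2 as follows: hydrogen in place of butyl on a saturated chain carbon bound to a selenium atom. For the measured compounds named here, no measured pair shows this change, so any step here rests on expectation alone. Compound 4 is expected to give 45000 nM, within a range of 15000 nM to 140000 nM. The expected step of a 1.3-fold higher number from compound 2 to compound 4 (0.11 log units; within the scatter) is small and may not reach beyond the scatter.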

Compound 4, concentration for 50% growth inhibition: 18000 nM
For compound 4 the middle estimate is 2.5-fold (0.40 log units) above the measured one; measured number inside the range.
By their numbers in this assay, from the lowest: compound 1; then compound 3; then compounds 4 and 2 (each within the scatter of the next).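

For the compounds shown here, replacing butyl with hydrogen on a saturated chain carbon bound to a selenium atom gives, in this assay, a 1.9-fold lower number from compound 2 to compound 4 (0.28 log units; within the scatter) and is the first pair to test this position. Going from pentyl to methyl therefore produces no difference that can be told from the scatter, so this assay does not register the loss of those four chain carbons. No supporting data bear on this outcome.

Going by these compounds, whether a benzyl group, a much longer chain, or a chain ending in an amine or a carboxylic acid would move the number beyond the scatter remains open. A single pair also cannot show whether the same holds on another core.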